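A few compounds are considered here, and "the series" means these few. Any claim that something is new, unique, unknown or untested is made for them only; others in the source may bear on it.

Measured compounds:
- compound 1, `COC(=O)c1cccc(-c2cnc(C(=O)CCc3ccc(-c4ccc(CN5CCCCC5)cc4)cc3)o2)n1`: 9 nM
- compound 2, `O=C(CCc1ccc(-c2ccccc2)cc1)c1ncc(C(=O)C(F)(F)F)o1`: 8 nM
- compound 3, `NC(=O)c1cccc(-c2cnc(C(=O)CCc3ccc(-c4ccccc4)cc3)o2)n1`: 1.2 nM

All three were tested in an assay for inhibition of Fatty-acid amide hydrolase 1 (Rattus norvegicus); on this read-out higher numbers stand for weaker inhibition and lower numbers for stronger inhibition. Compound 3 gives the lowest number of the three; the nearest is compound 2, and the gap between them, a 6.7-fold lower number from compound 2 to compound 3 (0.82 log units; beyond the scatter), lies beyond the usual scatter, as does the larger gap to compound 1. Compound 4, `COC(=O)c1cccc(-c2cnc(C(=O)CCc3ccc(-c4ccccc4)cc3)o2)n1`, has not been measured yet. It differs from compound 3 in one spot: methoxy in place of amino on a carbonyl carbon. Within the data shown here, no measured step changes exactly this group, so the measured step from compound 2 to compound 3 bears on it only indirectly, by showing that this end of the molecule can move the number by a modest amount. Compound 1 carries the same methoxycarbonyl group as compound 4 but differs elsewhere as well, so the value of compound 1, 9 nM, only hints that the ester may sit somewhat higher than compound 3. A small upward step, a 2.5-fold higher number from compound 3 to compound 4 (0.40 log units; beyond the scatter), is therefore expected. Compound 4 is estimated at 3 nM, within 1 nM to 10 nM.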

Compound 4, inhibition constant: 1.2 nM
For compound 4 the middle estimate is 2.5-fold (0.40 log units) above the measured one; low and high end bracket the measured number.
By their numbers in this assay, from the lowest: compounds 3 and 4 (each within the scatter of the next); then compounds 2 and 1 (each within the scatter of the next).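

In this assay, methoxy in place of amino on the carbonyl carbon gives no change at the digits printed from compound 3 to compound 4 (within the scatter), so at this position the carbamoyl and methoxycarbonyl groups cannot be told apart, even though the hydrogen-bond donor of the amino group is lost. The ester also matches the amide against the (trifluoromethyl)carbonyl group: the step of a 6.7-fold lower number from compound 2 to compound 4 (0.82 log units; beyond the scatter) has the same size as a 6.7-fold lower number from compound 2 to compound 3 (0.82 log units; beyond the scatter). With the ester now held constant, the far end of the molecule can be read as well: hydrogen in place of (piperidin-1-yl)methyl gives a 7.5-fold lower number from compound 1 to compound 4 (0.88 log units; beyond the scatter).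

From the compounds shown here alone, whether a carboxylic acid, an ethyl ester or a nitrile at this position would also read like the amide stays open. Nothing shown here explains why amide and methyl ester read alike.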